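The source may report more compounds than this note shows. Statements on the series, on what has been measured and on what is new or still open speak of the compounds shown alone.

Measured in an ADME assay on L02 cells (Homo sapiens) for antiproliferative activity, read by MTT assay, with a stated time of 48 h; on this read-out higher numbers stand for weaker inhibition and lower numbers for stronger inhibition:
- compound 1 `CCn1c(C(=O)NCCN)ccc1C(CC)(CC)c1ccc(OCCC(O)(CC)CC)c(C)c1`: 2940 nM
- compound 2 `CCOc1ccc(NC(=O)c2ccc(C(CC)(CC)c3ccc(OCCC(O)(CC)CC)c(C)c3)n2CC)cc1`: > 50000 nM (a limit)
- compound 3 `CCC(C)C(NC(=O)c1ccc(C(CC)(CC)c2ccc(OCCC(O)(CC)CC)c(C)c2)n1CC)C(=O)OC`: > 50000 nM (a limit)

Compound 3 gives a limit and not a number, and it sits with compound 2 at the limit of > 50000 nM in this assay, at which 2 of the 3 values shown sit. Compound 4 `CCOC(=O)C(CC(=O)OC)NC(=O)c1ccc(C(CC)(CC)c2ccc(OCCC(O)(CC)CC)c(C)c2)n1CC`, not yet measured, differs from compound 3 on the amide-type nitrogen: a group of 11 heavy atoms (7 carbon, 4 oxygen; no ring) in place of a group of 9 heavy atoms (7 carbon, 2 oxygen; no ring), on an amide-type nitrogen.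

Among the compounds with values here, two measured steps bear on this change, and both are large and beyond the scatter. One is an at least 17-fold higher number from compound 1 to compound 3 (1.23 log units; beyond the scatter), and the other is an at least 17-fold higher number from compound 1 to compound 2 (1.23 log units; beyond the scatter). Both leave the 2-aminoethyl group of compound 1, which compound 4 also lacks. The closest comparison is a step that the two limits leave unreadable from compound 2 to compound 3, so it gives no size. Compound 4 is therefore expected to stay with compound 2 and compound 3, with no step beyond the scatter and most likely another limit. The estimate means an expected a number no higher from compound 3 to compound 4 (the limit leaves the size open). For compound 4 the estimated value is 50000 nM, with an expected range from 20000 nM to 100000 nM.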

Compound 4, half-maximal inhibitory concentration: 4280 nM
Beside the measured number, compound 4's estimate is 12-fold (1.07 log units) above it, outside the stated range (below it).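

In this assay, the 2-aminoethyl group is not needed to stay clear of the limit on the amide-type nitrogen, as the group of 11 heavy atoms gives a 1.5-fold higher number from compound 1 to compound 4 (0.16 log units; within the scatter). A change between two ringless groups on this nitrogen can be large, with an at least 11-fold lower number from compound 3 to compound 4 (1.06 log units; beyond the scatter), and the group of 11 heavy atoms also separates from the 4-ethoxyphenyl group, with an at least 11-fold lower number from compound 2 to compound 4 (1.06 log units; beyond the scatter). Compound 2 and compound 3 remain limits rather than numbers: the limit of > 50000 nM in this assay, at which 2 of the 4 values shown sit.

Which part of the group of 11 heavy atoms carries the step stays open, as compound 3 and compound 4 differ across that whole group. Also open, as far as these compounds go, is how a carboxylic acid in place of an ester, or a longer chain ending in an amine, would read in this assay.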